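Rat plasma half-lives of a bicyclic diester series

The source may report more compounds than this note shows. Statements on the series, on what has been measured and on what is new or still open speak of the compounds shown alone.

Measured compounds:
compound 1, `CC(=O)Oc1ccccc1C(=O)O[C@H]1CO[C@H]2[C@@H]1OC[C@H]2OC(=O)c1ccccc1O`: 0.0825 h
compound 2, `COc1ccc(C(=O)O[C@@H]2CO[C@H]3[C@@H]2OC[C@@H]3OC(=O)c2ccccc2OC(C)=O)cc1`: 0.0525 h

For the measured compounds named here, both compounds share one core and have been tested in an ADME assay on a cell-free system (plasma, Homo sapiens) for metabolic stability, with Plasma (Rattus norvegicus) as the target, read by HPLC, at pH 7.4; on this read-out lower numbers stand for a shorter-lived compound and higher numbers for a longer-lived compound. Compound 1 gives 0.0825 h, the higher of the two numbers, and compound 2 gives 0.0525 h. Going by the values given here, the single measured step, a 1.6-fold lower number from compound 1 to compound 2 (0.20 log units; within the scatter), lies within the scatter, so the two values do not separate.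

Compound 3 `CC(=O)Oc1ccccc1C(=O)O[C@H]1CO[C@H]2[C@@H]1OC[C@H]2OC(=O)c1ccccc1OC(=O)c1ccccc1` is not yet measured. It differs from compound 1 by benzoyl in place of hydrogen on an oxygen on an aromatic ring. Among the compounds with values here, no measured step touches this oxygen: the only step, a 1.6-fold lower number from compound 1 to compound 2 (0.20 log units; within the scatter), exchanges the other aryl group on the core and stays within the scatter. The data therefore hold nothing that argues for a movement beyond the scatter in this assay, and a half-life close to that of compound 1 is expected.

The expected step is a 1.2-fold lower number from compound 1 to compound 3 (0.07 log units; within the scatter), which should remain within the scatter. Compound 3 is estimated at 0.07 h, with a range from 0.03 h to 0.16 h.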

Compound 3, half-life: 0.385 h
Estimate against measurement, compound 3: 5.5-fold (0.74 log units) below; the whole stated range lies below it.
By their numbers in this assay, from the lowest: compounds 2 and 1 (each within the scatter of the next); then compound 3.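

Benzoyl in place of hydrogen on this oxygen on an aromatic ring gives the only step in the series that lies beyond the scatter in this assay, a 4.7-fold higher number from compound 1 to compound 3 (0.67 log units; beyond the scatter), and the direction is towards a longer-lived compound. The earlier step exchanged the other aryl group on the core and stayed within the scatter, so this oxygen is the one place shown so far at which the half-life responds to a change, although that rests on a single pair of compounds. Nothing measured on these compounds bears on the reason for the rise, so the step stands as an observation only.

The compounds shown leave open whether the rise belongs to benzoyl specifically or would also appear with other groups on this oxygen, such as methyl, a pivaloyl group or a carbamate carrying an amine. They also leave open whether benzoyl on this oxygen would give a step of similar size with 4-methoxyphenyl or another aryl group at the other end of the core, and whether a longer half-life would follow from substituted benzoyl groups.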